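A further methoxy on compound 2

The source may report more compounds than this note shows. Statements on the series, on what has been measured and on what is new or still open speak of the compounds shown alone.

compound 1 `COc1cc(C(=O)NNC(=O)c2ccc3[nH]c(-c4ccc([N+](=O)[O-])s4)nc3c2)cc(OC)c1OC` | 31.3 ug/mL
compound 2 `COc1ccc(C(=O)NNC(=O)c2ccc3[nH]c(-c4ccc([N+](=O)[O-])o4)nc3c2)cc1OC` | 15.6 ug/mL

In a functional assay on K562 cells (Homo sapiens) for inhibition, read by sulforhodamine B assay, with a stated time of 48 h (on this read-out higher numbers stand for weaker inhibition of growth and lower numbers for stronger inhibition of growth), compound 2 gives 15.6 ug/mL and compound 1 gives 31.3 ug/mL as its value. These two numbers lie within the scatter of each other, so compound 2 cannot be separated from compound 1 on the present data. Compound 3 `COc1cc(C(=O)NNC(=O)c2ccc3[nH]c(-c4ccc([N+](=O)[O-])o4)nc3c2)cc(OC)c1OC` is related to compound 2 by a single change methoxy in place of hydrogen on an aromatic carbon that places methoxy in place of hydrogen on an aromatic carbon. Going by the values given here, no measured step isolates this change. The nearest evidence is compound 1, which carries the same set of methoxy groups as compound 3 but also differs from it elsewhere in the core. In this assay compound 1 gives 31.3 ug/mL without leaving the scatter of compound 2. A small shift toward a higher number is therefore expected, but none beyond the scatter. The expected change is a 1.3-fold higher number from compound 2 to compound 3 (0.11 log units; within the scatter) on this estimate. For compound 3 the estimated value is 20 ug/mL with an expected range from 7.8 ug/mL to 50 ug/mL in this measurement.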

Compound 3, concentration for 50% growth inhibition: 31.3 ug/mL
Compound 3: the middle estimate sits 1.6-fold (0.19 log units) below what was measured, within the range that was stated.
By their numbers in this assay, from the lowest: compounds 2, 1 and 3 (each within the scatter of the next).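

In this assay the step at this position, methoxy in place of hydrogen on an aromatic carbon ortho to a methoxy group, gives a 2.0-fold higher number from compound 2 to compound 3 (0.30 log units; within the scatter) and so stays inside what repeated measurements would scatter over; this aromatic carbon carries the further methoxy without a difference that these data can separate. The second single change, 5-nitrofuran-2-yl in place of 5-nitrothiophen-2-yl, gives no change at the digits printed from compound 1 to compound 3 (within the scatter) and shows that, with this set of methoxy groups, the two nitro-bearing rings cannot be told apart, which compounds 1 and 2 could not show because they differ in more than one place. Nothing measured here beyond these growth-inhibition values bears on either result.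

What the compounds shown leave open is whether a group other than methoxy on this aromatic carbon, such as an amine or a carboxylic acid, would move the number beyond the scatter. Also open, going by these compounds, is whether 5-nitrothiophen-2-yl and 5-nitrofuran-2-yl would remain inseparable with only the methoxy groups of compound 2 in place.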